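The source may hold more compounds than are shown below. What is called first, only, known or untested is meant among the compounds shown, and "the series" means these compounds.

In a functional assay (strain AB) with Danio rerio as the target, read by microscopy, with a stated time of 1 h (on this read-out lower numbers stand for an effect already at smaller amounts and higher numbers for an effect only at larger amounts of compound), three compounds built on one shared core have been measured. Compound 1 `CCN1CCc2c(sc(NC(=O)Nc3ccc(Cl)cc3)c2C(N)=O)C1` gives 3120 nM and compound 3 `COCCCN1CCc2c(sc(NC(=O)Nc3ccc(Cl)cc3)c2C(N)=O)C1` gives 2400 nM, so these two stand level within the usual scatter. Compound 2 `NC(=O)c1c(NC(=O)Nc2ccc(Cl)cc2)sc2c1CCN(CCCNC(=O)CCc1cccc3ccccc13)C2` gives 110 nM, a far lower number than compound 3 shows, well beyond the scatter.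

The next compound is compound 4 `NC(=O)c1c(NC(=O)Nc2ccc(Cl)cc2)sc2c1CCN(CCCNC(=O)CCc1cccnc1)C2`. It has ((2-(pyridin-3-yl)ethyl)carbonyl)amino in place of methoxy on a saturated chain carbon, three bonds along the chain from an amine nitrogen in a ring.

Within the data shown here, only one measured step bears on this place: a 1.3-fold lower number from compound 1 to compound 3 (0.11 log units; within the scatter), where methoxymethyl replaces hydrogen on the chain. That step lies within the scatter, so it gives little guidance for a much larger group. The better guide is compound 2, which also carries a carbonyl amino group on its chain and reaches 110 nM. Among the measured compounds shown here, its aromatic end differs from that of compound 4, however, and no measured step separates the two effects, so only part of that gain is expected to carry over.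

The step expected in this assay is therefore a 5.3-fold lower number from compound 3 to compound 4 (0.73 log units; beyond the scatter), beyond the scatter but uncertain in size. For compound 4 the estimated value is 450 nM, with an expected range from 110 nM to 2000 nM.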

Compound 4, half-maximal effective concentration: 470 nM
Estimate against measurement, compound 4: 1.0-fold (0.02 log units) below, within the range that was stated.
By their numbers in this assay, from the lowest: compound 2; then compound 4; then compounds 3 and 1 (each within the scatter of the next).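

In this assay, ((2-(pyridin-3-yl)ethyl)carbonyl)amino in place of methoxy gives a 5.1-fold lower number from compound 3 to compound 4 (0.71 log units; beyond the scatter), and setting the whole (((2-(pyridin-3-yl)ethyl)carbonyl)amino)methyl group in place of hydrogen gives a 6.6-fold lower number from compound 1 to compound 4 (0.82 log units; beyond the scatter), so on these compounds a clear gain at this position does not depend on a naphthalen-1-yl end. Among these compounds, that end still matters, however: pyridin-3-yl in place of naphthalen-1-yl gives a 4.3-fold higher number from compound 2 to compound 4 (0.63 log units; beyond the scatter), which separates the effect of the aromatic end from that of the chain, something the earlier compounds could not do. No measurement at hand explains why either end group or the added chain shifts the number in this way.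

The compounds shown leave open whether the gain comes from the carbonyl amino link alone or needs an aromatic ring at the end of the chain, a question that an acetylamino group on the same chain would address. Also open, as far as these compounds go, is how a plain phenyl end, or a longer chain carrying the same pyridin-3-yl end, would read in this assay.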